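This account rests on a few compounds, and the source may have more. Where it says the series, first, only, none or still open, it means among the compounds named here.

Going by these compounds, the account concerns a small set of closely related compounds and a single structural change whose effect is still open. Compound 1 `Nc1nc(Cl)c2ncn(Cc3ccccc3CCl)c2n1` carries an amino group on the shared core. In a functional assay on UO-31 cells (Homo sapiens) for cytotoxicity, read by sulforhodamine B assay, with a stated time of 48 h (on this read-out higher numbers stand for lower toxicity in this test and lower numbers for higher toxicity in this test), compound 1 gives > 100000 nM, which is a limit of the assay rather than a measured number. Compound 2 `ClCc1ccccc1Cn1cnc2nc(Cl)nc(Cl)c21` is a close relative of compound 1. In this assay compound 2 gives "not determined" (no result reported), so no value stands for it at all. Going by the values given here, compound 1 therefore sits at the limit of > 100000 nM in this assay, at which 1 of the 2 values shown sits, and the only other entry adds no number, leaving no measured step between compounds to lean on. Compound 3 `ClCc1ccccc1Cn1cnc2c(Cl)ncnc21` remains to be measured in this assay. It differs from compound 1 by hydrogen in place of amino on an aromatic carbon. With compound 1 already at the limit and nothing to set the change against, the step from compound 1 to compound 3 is expected to be a number no higher from compound 1 to compound 3 (the limit leaves the size open), none beyond the scatter, and the result is likely to come back again as a limit. Compound 3 is thus estimated at 100000 nM, in a range from 30000 nM to 400000 nM.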

Compound 3, concentration lethal to 50% of the cells: 61700 nM
For compound 3 the middle estimate is 1.6-fold (0.21 log units) above the measured one; low and high end bracket the measured number.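

With hydrogen in place of amino on the aromatic carbon between two ring nitrogen atoms, this assay gives a single number for the first time among these compounds, and the step is an at least 1.6-fold lower number from compound 1 to compound 3 (0.20 log units; that floor lies within the scatter) on a read-out where lower numbers stand for higher toxicity in this test. This shows that, without the amino group, compound 3 falls inside the range the test can read, while the printed floor of the step does not by itself set the change apart from the usual scatter. Going by these compounds, the true size of the step stays open because compound 1 stands at a limit of the assay: the limit of > 100000 nM in this assay, at which 1 of the 3 values shown sits.

On these data alone, compound 2 has no reported result, so any step to it cannot be read, and the effect of a chloro group at this carbon stays unknown. The compounds shown also leave open how a methylamino or a methoxy group on this aromatic carbon would read, and whether either would fall closer to compound 1 or to compound 3.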